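Aryl substituent changes on a shared imidazole series

The compounds below may be only part of what the source reports. "The series", "measured", "known", "first", "only" and "open" are said of these compounds alone.

Measured compounds:
compound 1 `CCC(C)(C)Cc1c[nH]c(CCc2ccc(-n3ncnn3)cc2)n1` — 99 nM
compound 2 `CCC(C)(C)Cc1c[nH]c(CCc2ccc(-c3cnccn3)cc2)n1` — 107 nM
compound 3 `CCC(C)(C)Cc1c[nH]c(CCc2ccc(N3CCCCC3)cc2)n1` — 133 nM

All three were tested in a functional assay on HEK293 cells for agonist activity at Bombesin receptor subtype-3 (Mus musculus), read by luminescence and calcium flux, with a stated time of 10 min; on this read-out lower numbers stand for an effect already at smaller amounts and higher numbers for an effect only at larger amounts of compound. Compound 2 stands in the middle of the three numbers; its nearest neighbour is compound 1, at a 1.1-fold higher number from compound 1 to compound 2 (0.03 log units; within the scatter), and its furthest is compound 3, at a 1.2-fold higher number from compound 2 to compound 3 (0.09 log units; within the scatter). The remaining pair, compound 1 to compound 3, shows a 1.3-fold higher number from compound 1 to compound 3 (0.13 log units; within the scatter). So far, exchanging the group on the aromatic carbon of the six-membered ring of carbon only has not moved the read-out beyond the scatter.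

Compound 4 `CCC(C)(C)Cc1c[nH]c(CCc2ccc(-c3cccnc3C(=O)O)cc2)n1` is not yet measured. It differs from compound 2 in one place: 2-carboxypyridin-3-yl in place of pyrazin-2-yl on an aromatic carbon. The bearing steps are those from compound 1 to compound 2 and from compound 2 to compound 3, both within the scatter. Within the data shown here, none of them adds a carboxylic acid, so the change to 2-carboxypyridin-3-yl has no direct precedent here, and the expectation rests on the tolerance of this position in compounds 1 to 3.

For compound 4 the expected read-out in this assay is 160 nM, with a range of 50 nM to 600 nM; the estimate implies a step of a 1.5-fold higher number from compound 2 to compound 4 (0.17 log units; within the scatter), with widened uncertainty.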

Compound 4, half-maximal effective concentration: 97 nM
Estimate against measurement, compound 4: 1.6-fold (0.22 log units) above, and the stated range covers the measured number.
By their numbers in this assay, from the lowest: compounds 4, 1, 2 and 3 (each within the scatter of the next).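

In this assay, the aromatic carbon para to a large group also tolerates 2-carboxypyridin-3-yl, which, unlike pyrazin-2-yl, brings a hydrogen-bond donor, oxygen and more heavy atoms: the read-out shows a 1.1-fold lower number from compound 2 to compound 4 (0.04 log units; within the scatter), alongside a 1.0-fold lower number from compound 1 to compound 4 (0.01 log units; within the scatter) and a 1.4-fold lower number from compound 3 to compound 4 (0.14 log units; within the scatter). A carboxylic acid, absent from compounds 1 to 3, therefore adds no step beyond the scatter, and the tolerance seen with 2H-tetrazol-2-yl, pyrazin-2-yl and piperidin-1-yl now extends to a group of a different kind, within these four compounds only. No supporting data are available to account for this tolerance.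

Still open is whether an amine, a methyl ester in place of the carboxylic acid, or a longer alkyl chain on this aromatic carbon would move the read-out beyond the scatter, as no step among these four compounds does. Also open is whether a phenyl ring carrying a carboxylic acid, without the pyridine nitrogen, would give a number within the scatter of these compounds in this assay.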